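The compounds below may be only part of what the source reports. "The series", "measured", "known", "first", "only" and "open" are said of these compounds alone.

Compound 1 `CC[C@@H]1O[C@H](COCc2ccccc2)[C@@H](OCc2ccccc2)[C@H](OCc2ccccc2)[C@H]1O` gives 34200 nM in a functional assay on HOS cells (Homo sapiens) for antiproliferative activity, read by sulforhodamine B assay; a lower number here means a stronger inhibitor of growth, a higher number a weaker inhibitor of growth.
Compound 2 `CCC[C@@H]1O[C@H](COCc2ccccc2)[C@@H](OCc2ccccc2)[C@H](OCc2ccccc2)[C@H]1O` gives 38600 nM in this assay.
Compound 3 `CCC[C@@H]1O[C@H](COCc2ccccc2)[C@@H](OCc2ccccc2)[C@H](OCc2ccccc2)C1=O` gives only a limit in this assay, > 50000 nM.

Compound 2 differs from compound 1 by methyl in place of hydrogen on a saturated chain carbon, two bonds along the chain from a saturated ring carbon, and the step is a 1.1-fold higher number from compound 1 to compound 2 (0.05 log units; within the scatter). How the core of compound 3 differs from the core of compound 1 is not broken down here. Compound 4 `CC(C)C[C@@H]1O[C@H](COCc2ccccc2)[C@@H](OCc2ccccc2)[C@H](OCc2ccccc2)C1=O` is not yet measured; it differs from compound 3 by methyl in place of hydrogen on a saturated chain carbon bound to two saturated chain carbons. This is the same kind of change as from compound 1 to compound 2, though the place differs: there the carbon was two bonds along the chain from a saturated ring carbon, here it is bound to two saturated chain carbons. Since compound 3 sits at the limit of > 50000 nM in this assay, at which 1 of the 3 values shown sits, and the earlier step was small, compound 4 is expected to give roughly 60000 nM, most likely again only a limit, between 30000 nM and 150000 nM, a step that the limit leaves unreadable from compound 3 to compound 4.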

Compound 4, concentration for 50% growth inhibition: > 50000 nM
Compound 4: only a limit was reported; the forecaster's own chance of this, stated with the estimate: 70%; the middle value lies beyond the limit too.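

The step from compound 3 to compound 4 cannot be read, as both results are limits of this assay and not numbers. As far as these compounds go, whether the extra methyl changes growth inhibition on the core of compound 3 stays open.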